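Fluoro for methyl on the solubility of compound 2

The source may report more compounds than this note shows. Statements on the series, on what has been measured and on what is new or still open speak of the compounds shown alone.

Measured compounds:
- compound 1 `Cc1cc(Cl)c(-c2ncc[nH]2)cc1NC(=O)c1ccc(OCc2ccccn2)cc1`; in a physicochemical assay for solubility, at pH 7.4 (on this read-out higher numbers stand for higher solubility and lower numbers for lower solubility), compound 1 sits at a limit of the assay, < 1000 nM
- compound 2 `Cc1cc(C)c(-c2ncc[nH]2)cc1NC(=O)c1ccc(OCc2ccccn2)cc1`; compound 2 gives 2000 nM
- compound 3 `Cc1cc(C)c(-c2cn(C)cn2)cc1NC(=O)c1ccc(OCc2ccccn2)cc1`; compound 3 gives 8000 nM

Compound 2 stands lowest of the two numbers shown in this assay; its nearest neighbour is compound 3, with a 4.0-fold higher number from compound 2 to compound 3 (0.60 log units; beyond the scatter). The third value, that of compound 1, is a limit rather than a number (the limit of < 1000 nM in this assay, at which 1 of the 3 values shown sits).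

The next compound is compound 4 `Cc1cc(F)c(-c2ncc[nH]2)cc1NC(=O)c1ccc(OCc2ccccn2)cc1`. It differs from compound 2 in one place: fluoro in place of methyl on an aromatic carbon.

Going by the values given here, only one measured step touches the same position: an at least 2.0-fold higher number from compound 1 to compound 2 (0.30 log units; that floor lies within the scatter), which goes from a halogen to methyl. Compound 4 reverses that direction, going from methyl to a halogen, though a different one. The step from compound 1 to compound 2 reaches only the floor set by the limit, so its true size is open. The change from compound 2 to compound 3 concerns the other ring and does not bear on this step.

The expectation for compound 4 in this assay is therefore a small move downward from compound 2, a 1.4-fold lower number from compound 2 to compound 4 (0.15 log units; within the scatter), possibly none beyond the scatter. Compound 4 is estimated at 1400 nM, between 600 nM and 3500 nM.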

Compound 4, solubility: 1000 nM
Estimate against measurement, compound 4: 1.4-fold (0.15 log units) above, within the range that was stated.
By their numbers in this assay, from the lowest: compounds 4 and 2 (each within the scatter of the next); then compound 3.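

In this assay, going by these compounds alone, fluoro in place of methyl, on the aromatic carbon ortho to the 1H-imidazol-2-yl group, gives a 2.0-fold lower number from compound 2 to compound 4 (0.30 log units; within the scatter), the first step at this position with a number at both ends, and this read-out does not separate the two groups there. Within the data shown here, compound 1 stands at a limit, so the size of a number no lower from compound 1 to compound 4 (the limit leaves the size open), the only comparison of the two halogens at this position, cannot be read because of it: the limit of < 1000 nM in this assay, at which 1 of the 4 values shown sits. Among these compounds, the only step printed as beyond the scatter therefore remains a 4.0-fold higher number from compound 2 to compound 3 (0.60 log units; beyond the scatter), which lies at the 1H-imidazol-2-yl group and not at the position of the fluoro, methyl and chloro groups.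

Open, from the compounds shown here alone, is whether an amine or a carboxylic acid on this same aromatic carbon would give a step beyond the scatter from compound 2. Also open, going by these compounds, is whether fluoro in place of methyl gives a step of similar size when 1-methyl-1H-imidazol-4-yl stands in place of 1H-imidazol-2-yl, as in compound 3.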